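From 2-chlorophenyl to 3-bromophenyl on a shared core

The source may hold more compounds than are shown below. What is called first, only, known or untested is meant among the compounds shown, and "the series" means these compounds.

Compound 1 `Cn1c(-c2ccccc2)cnc1NC(=O)c1ccccc1`: > 100000 nM (a limit)
Compound 2 `Cc1ccc(C(=O)Nc2ncc(-c3ccccc3)n2C)cc1`: > 50000 nM (a limit)
Compound 3 `Cn1c(-c2ccccc2)cnc1NC(=O)c1ccccc1Cl`: > 50000 nM (a limit)

These three results come from a toxicity assay on THP-1 cells (Homo sapiens) for inhibition; on this read-out higher numbers stand for lower toxicity in this test and lower numbers for higher toxicity in this test. Compound 3 stands only at a limit, > 50000 nM, and so do the other two compounds. Compound 4 `Cn1c(-c2ccccc2)cnc1NC(=O)c1cccc(Br)c1` carries 3-bromophenyl in place of 2-chlorophenyl on a carbonyl carbon.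

Going by the values given here, three measured steps bear on this change: a step that the two limits leave unreadable from compound 1 to compound 2, a step that the two limits leave unreadable from compound 1 to compound 3 and a step that the two limits leave unreadable from compound 2 to compound 3. None of them has a size that can be read, so they point in no direction. Resting on the limit of compound 3, > 50000 nM, no step beyond the usual scatter is expected in this assay, and a limit may well be reported again. The expected change is a number no higher from compound 3 to compound 4 (the limit leaves the size open). For compound 4 the estimated value is 50000 nM. The expected range for compound 4 runs from 20000 nM to 100000 nM.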

Compound 4, half-maximal cytotoxic concentration: > 50000 nM
Compound 4: a limit, no number; the forecaster's own chance of this, stated with the estimate: 70%; the middle value sits exactly at the limit.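

Going by these compounds alone, compound 4, like compound 1, compound 2 and compound 3, stands only at a limit in this assay, so no new step from any of them to compound 4 can be read. The compounds shown leave open whether changing the group on the carbonyl carbon alters toxicity at all.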